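A few compounds are considered here, and "the series" means these few. Any claim that something is new, unique, unknown or untested is made for them only; others in the source may bear on it.

Series notes, amide substituent on the shared core. Compound 1 `CCCn1c(SCc2cc([N+](=O)[O-])ccc2OC)nc2cc(NC(=O)NC(C)(C)C)cc(C(=O)NC(C)(C)C)c21` gives in an assay on isolated protein for inhibition of Gonadotropin-releasing hormone receptor (Homo sapiens) (a lower number here means a stronger inhibitor, a higher number a weaker inhibitor), 410 nM. Compound 2 `CCCn1c(SCc2cc([N+](=O)[O-])ccc2OC)nc2cc(NC(=O)NC(C)(C)C)cc(C(=O)NCc3ccncc3)c21` gives in this assay 61 nM. Within the data shown here, the one step measured so far, a 6.7-fold lower number from compound 1 to compound 2 (0.83 log units; beyond the scatter), places compound 2 at the lower of the two numbers, with compound 1 the only neighbour. Compound 3 `CCCn1c(SCc2cc([N+](=O)[O-])ccc2OC)nc2cc(NC(=O)NC(C)(C)C)cc(C(=O)NCCCN(C)C)c21` is the next change at the same amide-type nitrogen: 2-(dimethylamino)ethyl in place of pyridin-4-yl on a saturated chain carbon bound to an amide-type nitrogen. Among the measured compounds shown here, the only step that bears on this position is a 6.7-fold lower number from compound 1 to compound 2 (0.83 log units; beyond the scatter), and it shows that exchanging the group on this nitrogen can move the number by a modest amount. No measured pair exchanges an aromatic group for an open chain at this place, so the direction cannot be read from the shown steps. A change within the scatter or a modest rise toward the region of compound 1 is expected in this assay. Compound 3 is therefore estimated at 110 nM, within 30 nM to 400 nM, meaning an expected step of a 1.8-fold higher number from compound 2 to compound 3 (0.26 log units; within the scatter).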

Compound 3, half-maximal inhibitory concentration: 170 nM
Estimate against measurement, compound 3: 1.5-fold (0.19 log units) below; the measured number falls inside the stated range.
By their numbers in this assay, from the lowest: compound 2; then compound 3; then compound 1.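

Among these compounds, compound 3 puts an open chain on the amide-type nitrogen for the first time, and in this assay the exchange of (pyridin-4-yl)methyl for 3-(dimethylamino)propyl gives a 2.8-fold higher number from compound 2 to compound 3 (0.45 log units; beyond the scatter). Aromatic ring and open chain are therefore not interchangeable at this place, although the ring is not needed for all of the gain over tert-butyl, since the chain alone gives a 2.4-fold lower number from compound 1 to compound 3 (0.38 log units; beyond the scatter). Among these three compounds, both groups that carry a nitrogen give lower numbers than tert-butyl, and compound 1 is the only compound without one, but nothing in the data shown explains either step.

On these data alone, it remains open whether the nitrogen in either group matters, as no comparison is available with a benzyl group, which has the ring without its nitrogen, or with a plain butyl chain, which has no terminal amine. Also unresolved is how the number responds to chain length or to the terminal group, for example with a 2-(dimethylamino)ethyl chain, a morpholine at the chain end or a carboxylic acid in place of the amine.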